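Cytotoxicity notes: dimethylamino on the phenoxy ring

The source may hold more compounds than are shown below. What is called first, only, known or untested is meant among the compounds shown, and "the series" means these compounds.

Measured so far:
compound 1 `c1ccc(Oc2ccc3c(NCCCNCc4ccco4)ccnc3c2)cc1` — 15200 nM
compound 2 `COc1cccc(CNCCCNc2ccnc3cc(Oc4ccccc4)ccc23)c1O` — 6800 nM
compound 3 `COc1ccc(F)cc1CNCCCNc1ccnc2cc(-c3ccc(C(C)(C)C)cc3)ccc12` — 620 nM

In an ADME assay on HepG2 cells (Homo sapiens) for cytotoxicity, read by luminescence, CellTiter-Glo and ATP content, with a stated time of 72 h (on this read-out higher numbers stand for an effect only at larger amounts of compound and lower numbers for an effect already at smaller amounts), compound 1 gives 15200 nM, the highest of the three numbers; compound 2 lies nearest with 6800 nM, compound 3 furthest with 620 nM. For the measured compounds named here, the one step between compounds that differ in a single place runs from compound 1 to compound 2: a 2.2-fold lower number from compound 1 to compound 2 (0.35 log units; beyond the scatter), a modest shift beyond the scatter, and it concerns the amine end of the chain, not the phenoxy ring. Compound 3 differs from the others in more than one place and gives no single-place comparison.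

Compound 4 `CN(C)c1cccc(Oc2ccc3c(NCCCNCc4ccco4)ccnc3c2)c1` is the next entry and stands against compound 1 by dimethylamino in place of hydrogen on an aromatic carbon. Going by the values given here, no measured step touches this position: both the ring carrying the change and the group that enters are without a counterpart in the set. Among the compounds with values here, the only step, from compound 1 to compound 2, is modest and sits elsewhere, so for this assay no change beyond the scatter is expected, with a slight lean toward a lower number. The estimated step is a 1.4-fold lower number from compound 1 to compound 4 (0.14 log units; within the scatter), which rests on the absence of any bearing step rather than on one. Compound 4 is therefore expected at 11000 nM, within 4000 nM to 30000 nM.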

Compound 4, half-maximal effective concentration: 16000 nM
The estimate for compound 4 lay 1.5-fold (0.16 log units) below the measured number; the measured number falls inside the stated range.
By their numbers in this assay, from the lowest: compound 3; then compound 2; then compounds 1 and 4 (each within the scatter of the next).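

In this assay, the phenoxy ring of the series now has its first measured substitution, and the outcome (a 1.1-fold higher number from compound 1 to compound 4 (0.02 log units; within the scatter)) places compound 1 and compound 4 within the scatter of each other. For the compounds shown here, for this one group at this one place, on an aromatic carbon meta to a large group, 3 heavy atoms enter and the read-out gives no distinguishable difference, whereas the only earlier single-place step, from furan-2-yl to 2-hydroxy-3-methoxyphenyl, lay at the amine end of the chain. No supporting data bear on why this substitution gives this result.

Open, as far as these compounds go, is whether this holds for other groups on the same carbon, such as a carboxylic acid, a primary amine or a longer chain carrying a terminal amine, since a single group cannot show how broad the pattern is. Also open, from the compounds shown here alone, is whether dimethylamino gives the same outcome at other places on the phenoxy ring, or when the furan-2-yl end of compound 4 is replaced by the 2-hydroxy-3-methoxyphenyl end of compound 2.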